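Dipropylamino in Place of Piperidinyl on a Sulfonyl Sulfur

A few compounds are considered here, and "the series" means these few. Any claim that something is new, unique, unknown or untested is made for them only; others in the source may bear on it.

Compound 2 `CCOC(=O)[C@@H]1CCCN(S(=O)(=O)c2ccc(S(=O)(=O)N3CCCCC3)cc2)C1` is one of three close relatives examined in a functional assay on MIA PaCa-2 cells (Homo sapiens) for inhibition, read by MTT assay, with a stated time of 3 days; a higher number here means a weaker inhibitor, a lower number a stronger inhibitor. In this assay compound 2 gives > 10000 nM, which is a limit of the assay and not a number. Compound 1 `CCOC(=O)[C@@H]1CCCN(S(=O)(=O)c2ccc(S(=N)(=O)N(CC)CC)cc2)C1` differs from compound 2 at a single aromatic carbon, and in this assay compound 1 gives > 10000 nM, likewise a limit. The step that the two limits leave unreadable from compound 1 to compound 2 is therefore unreadable in size and direction. Compound 3 `CCN1CC(NC(=O)[C@@H]2CCCN(S(=O)(=O)c3ccc(S(=O)(=O)N(CC)CC)cc3)C2)C1` is the third relative, and in this assay compound 3 gives > 10000 nM, again a limit. Going by the values given here, every value shown sits at the limit of > 10000 nM in this assay, at which 3 of the 3 values shown sit, so no measured step provides a scale for the change now considered.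

Compound 4 `CCCN(CCC)S(=O)(=O)c1ccc(S(=O)(=O)N2CCC[C@@H](C(=O)OCC)C2)cc1` is yet to be measured. It differs from compound 2 in one place: dipropylamino in place of piperidin-1-yl on a sulfonyl sulfur. Among the compounds with values here, the only measured step at a comparable place is unreadable because both of its values rest at the limit of > 10000 nM in this assay, at which 3 of the 3 values shown sit. With three limits and no readable step, the account rests on the observation that every relative so far has stayed beyond the assay's reach. Compound 4 is thus expected to remain at or near that limit, and the estimated step that the limit leaves unreadable from compound 2 to compound 4 is taken to lie within the usual scatter. For compound 4 the estimate is 15000 nM, with an expected range from 5000 nM to 50000 nM.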

Compound 4, half-maximal inhibitory concentration: > 10000 nM
Compound 4: no number, only a limit; the forecaster's own chance of this, stated with the estimate: 85%; the middle value lies beyond the limit too.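

Compound 4 joins compound 1 and compound 2 at a limit rather than a number, so neither step to compound 4 can be read, because all the values shown rest at one boundary: the limit of > 10000 nM in this assay, at which 4 of the 4 values shown sit.

The compounds shown leave open whether dipropylamino and piperidin-1-yl on a sulfonyl sulfur differ at all, and which change to the shared core would yield a measurable value.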